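Swapping a Carboxyphenyl for a Dichlorophenyl Amide

This account rests on a few compounds, and the source may have more. Where it says the series, first, only, none or still open, it means among the compounds named here.

Measured so far:
Compound 1, `O=C(Nc1cc(-c2ccccc2)nn1-c1ccccc1)c1cccc([N+](=O)[O-])c1`, gives 2220 nM in an assay on HEK293 cells for displacement of a labelled ligand from metabotropic glutamate receptor 5 (Rattus norvegicus); a lower number here means a stronger inhibitor, a higher number a weaker inhibitor.
Compound 2, `O=C(Nc1cc(-c2ccccc2)nn1-c1ccccc1)c1ccc(C(F)(F)F)cc1`, gives 990 nM in this assay.
Compound 3, `O=C(O)c1ccc(C(=O)Nc2cc(-c3ccccc3)nn2-c2ccccc2)cc1`, gives > 10000 nM in this assay, which is a limit of the assay and not a number.

Compound 3 therefore stands at the weak end of the three, with its result sitting at the limit of > 10000 nM in this assay, at which 1 of the 3 values shown sits, so its true number is not known. Compound 4, `O=C(Nc1cc(-c2ccccc2)nn1-c1ccccc1)c1ccc(Cl)c(Cl)c1`, is not yet measured. It differs from compound 3 by 3,4-dichlorophenyl in place of 4-carboxyphenyl on a carbonyl carbon. Among the measured compounds shown here, two measured steps bear on this change. The closest is an at least 10-fold higher number from compound 2 to compound 3 (1.00 log units; beyond the scatter), which runs the opposite way: the same carbonyl position carrying a trifluoromethyl-bearing ring instead of a carboxy-bearing ring. The other, a 2.2-fold lower number from compound 1 to compound 2 (0.35 log units; beyond the scatter), places the trifluoromethyl ring at the strong end of what has been seen. Since the dichlorophenyl of compound 4 resembles the trifluoromethyl ring of compound 2 more than the carboxyphenyl of compound 3, the move from compound 3 to compound 4 is expected to reverse the earlier loss, giving roughly an at least 11-fold lower number from compound 3 to compound 4 (1.04 log units; beyond the scatter). The estimate for compound 4 in this assay is 900 nM, with a range from 300 nM to 3000 nM.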

Compound 4, inhibition constant: 160 nM
Compound 4: middle estimate off by 5.6-fold (0.75 log units), on the high side; the whole stated range lies above it.
By their numbers in this assay, from the lowest: compound 4; then compound 2; then compound 1. At a limit, above all of these: compound 3.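

Compound 4 shows that this position, a carbonyl carbon whose other neighbour is an amide-type nitrogen, can reach well past the strongest result the earlier rings gave in this assay: the change to 3,4-dichlorophenyl gives a 6.2-fold lower number from compound 2 to compound 4 (0.79 log units; beyond the scatter), and a 14-fold lower number from compound 1 to compound 4 (1.14 log units; beyond the scatter). Set against the ring with the carboxy group, the same change gives an at least 62-fold lower number from compound 3 to compound 4 (1.79 log units; beyond the scatter), so the ring on this carbonyl carbon can move the result far in both directions, and compound 4 now stands as the strongest of the four. The true size of that last step is unknown, since compound 3 holds a limit of the assay and not a number: the limit of > 10000 nM in this assay, at which 1 of the 4 values shown sits.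

The compounds shown cannot say whether a ring with a single chlorine would do as well as 3,4-dichlorophenyl, since no compound here separates the two chlorine atoms. From the compounds shown here alone, how a ring carrying an amine, a methoxy group or a longer chain would behave at this position also stays open, as does whether the gain would hold with any change elsewhere on the shared core.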